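This account rests on a few compounds, and the source may have more. Where it says the series, first, only, none or still open, it means among the compounds named here.

Compounds measured:
compound 1 `O=C(Nc1cc(-c2ccccc2)nn1-c1ccccc1)c1cccc(F)c1` — 65 nM
compound 2 `O=C(Nc1cc(-c2ccccc2)nn1-c1ccccc1)c1ccc(Cl)cc1` — 100 nM

Within the data shown here, in an assay on isolated protein with metabotropic glutamate receptor 5 (Rattus norvegicus) as the target (a higher number here means that more compound is needed for the effect, a lower number that less compound is needed), compound 1 gives 65 nM, the lowest of the two numbers, and the only other number lies a 1.5-fold higher number from compound 1 to compound 2 (0.19 log units; within the scatter). Compound 3 `O=C(Nc1cc(-c2ccccc2)nn1-c1ccccc1)c1ccc(C(F)(F)F)cc1` differs from compound 1 by 4-(trifluoromethyl)phenyl in place of 3-fluorophenyl on a carbonyl carbon. Among the measured compounds shown here, the one measured step that bears on this, the change to a 4-chlorophenyl, was a 1.5-fold higher number from compound 1 to compound 2 (0.19 log units; within the scatter) and stayed within the scatter. No clear step beyond the scatter, or at most a modest rise, is therefore expected in this assay. Compound 3 is estimated at 120 nM (range 40 nM to 400 nM), which would be an expected 1.8-fold higher number from compound 1 to compound 3 (0.27 log units; within the scatter).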

Compound 3, half-maximal effective concentration: 20 nM
Beside the measured number, compound 3's estimate is 6.0-fold (0.78 log units) above it, outside the stated range (below it).
By their numbers in this assay, from the lowest: compound 3; then compounds 1 and 2 (each within the scatter of the next).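

In this assay the group on the carbonyl carbon proves able to move the number beyond the scatter, which the first pair did not show: 4-(trifluoromethyl)phenyl in place of 3-fluorophenyl gives a clear drop (a 3.3-fold lower number from compound 1 to compound 3 (0.51 log units; beyond the scatter)). Trifluoromethyl in place of chloro on an aromatic carbon also gives a drop (a 5.0-fold lower number from compound 2 to compound 3 (0.70 log units; beyond the scatter)), so compound 3 has the lowest number of the three. No evidence is available to explain this result. From the compounds shown here alone, whether a nitrile or a methoxy group in place of the trifluoromethyl would keep the number of compound 3 remains open.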